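Fluoro to trifluoromethyl on the aryl: notes on four compounds

The source may report more compounds than this note shows. Statements on the series, on what has been measured and on what is new or still open speak of the compounds shown alone.

Measured so far:
compound 1 `CCC(C(=O)N1CCN(c2cccc(F)c2)CC1)N1C(=O)CCC1=O`: 0%
compound 2 `CC(C(=O)N1CCN(c2ccccc2F)CC1)N1C(=O)CCC1=O`: 0%
compound 3 `CC(C(=O)N1CCN(c2ccccc2C(F)(F)F)CC1)N1C(=O)CCC1=O`: 25%

In a functional assay on the whole organism (strain Swiss) with Mus musculus as the target, in the maximal electroshock model, with a stated time of 0.5 h, at a dose of 100 mg/kg by the intraperitoneal route (on this read-out higher numbers stand for a stronger effect at the one dose given and lower numbers for a weaker effect), compound 1 gives 0%, and compound 2 gives 0%; the two numbers are the same at the digits reported. The difference between the cores of compound 1 and compound 2 is not broken down here. Compound 3 gives 25% in this assay. The change trifluoromethyl in place of fluoro on an aromatic carbon brought a number 25 percentage points higher from compound 2 to compound 3 (beyond the scatter).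

Compound 4 `CCC(C(=O)N1CCN(c2cccc(C(F)(F)F)c2)CC1)N1C(=O)CCC1=O` is not yet measured. It arises from compound 1 by trifluoromethyl in place of fluoro on an aromatic carbon, the same kind of change as from compound 2 to compound 3, but the place differs: ortho to a large group there, meta to a large group here. Within the data shown here, with compound 1 at 0%, and the only comparable step being a number 25 percentage points higher from compound 2 to compound 3 (beyond the scatter), compound 4 is expected to rise by about a number 20 percentage points higher from compound 1 to compound 4 (beyond the scatter) in this assay. Among the measured compounds shown here, a somewhat smaller step is estimated for compound 4, since the place is not the same and only one example of the change exists. The estimate for compound 4 is 20%, from 0% to 45%.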

Compound 4, a percentage reported as activity, at one dose (the size of the read-out at that dose, not a potency): 50%
Compound 4: middle estimate off by 30 percentage points, on the low side; the whole stated range lies below it.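

Trifluoromethyl in place of fluoro on an aromatic carbon raises the read-out in this assay on both cores, and on the core of compound 1 the change brings a number 50 percentage points higher from compound 1 to compound 4 (beyond the scatter). The direction of the step carries from one core to the other, but its size does not: the same change on two cores in this assay, a number 25 percentage points higher (beyond the scatter) from compound 2 to compound 3 and a number 50 percentage points higher (beyond the scatter) from compound 1 to compound 4, 25 percentage points apart, beyond the scatter of two such steps. The two pairs differ both in the core and in the place of the change, which is meta to a large group in compound 4, and two pairs cannot tell these differences apart, so they give no reason for the gap and no size to forecast on a further core.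

The compounds shown leave open how other groups on the same aromatic carbon, such as chloro, methoxy or a nitrile, compare with fluoro and trifluoromethyl. Also open, going by these compounds, is whether a longer chain on the shared core would change the size of the step.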